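Cytotoxicity notes on a hydrazone-linked chloroquinoline series

The source may hold more compounds than are shown below. What is called first, only, known or untested is meant among the compounds shown, and "the series" means these compounds.

Measured so far:
- compound 1, `O=C(/C=N/OCc1ccc([N+](=O)[O-])cc1)NCCCCCCCNc1ccnc2cc(Cl)ccc12`: 1700 nM
- compound 2, `O=C(/C=N/NCc1ccccc1)NCCCCCCCNc1ccnc2cc(Cl)ccc12`: 14600 nM
- compound 3, `O=C(/C=N/Nc1ccnc2cc(Cl)ccc12)NCCCCCCCNc1ccnc2cc(Cl)ccc12`: 1400 nM

In a functional assay on MRC5 cells (Homo sapiens) for cytotoxicity, read by colorimetric assay and MTT assay (a higher number here means that more compound is tolerated, a lower number that less compound is tolerated), compound 3 gives the lowest number of the three; compound 1 stands within the scatter of it (a 1.2-fold lower number from compound 1 to compound 3 (0.08 log units; within the scatter)), while compound 2 lies apart (a 10-fold lower number from compound 2 to compound 3 (1.02 log units; beyond the scatter)).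

Compound 4, `COc1ccc2nc(N/N=C/C(=O)NCCCCCCCNc3ccnc4cc(Cl)ccc34)nnc2c1`, is not yet measured. It differs from compound 3 only at the amine nitrogen: a group of 12 heavy atoms (8 carbon, 3 nitrogen, 1 oxygen; one six-membered aromatic ring of carbon only, one six-membered aromatic ring with 3 hetero atoms) in place of a group of 11 heavy atoms (9 carbon, 1 nitrogen, 1 chlorine; one six-membered aromatic ring of carbon only, one six-membered aromatic ring with 1 hetero atom), on an amine nitrogen.

Among the measured compounds shown here, the one step bearing on this position is the exchange of benzyl for 7-chloroquinolin-4-yl (a 10-fold lower number from compound 2 to compound 3 (1.02 log units; beyond the scatter)), a large move; the exchange on the double-bonded nitrogen (a 1.2-fold lower number from compound 1 to compound 3 (0.08 log units; within the scatter)) changed nothing beyond scatter. For the measured compounds named here, no measured step exchanges one bicyclic aromatic group for another at this place, so the direction is open. A modest rise is expected, a 1.8-fold higher number from compound 3 to compound 4 (0.25 log units; within the scatter), giving an estimate for compound 4 of 2500 nM (range 800 nM to 8000 nM).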

Compound 4, half-maximal cytotoxic concentration: 2500 nM
Compound 4: the middle estimate sits on the measured number at the digits printed, and the stated range covers the measured number.
By their numbers in this assay, from the lowest: compounds 3, 1 and 4 (each within the scatter of the next); then compound 2.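

At this amine nitrogen, one bicyclic aromatic group can replace another with no change beyond the scatter: a 1.8-fold higher number from compound 3 to compound 4 (0.25 log units; within the scatter) in this assay. The group of 12 heavy atoms also stands apart from benzyl, a 5.8-fold lower number from compound 2 to compound 4 (0.77 log units; beyond the scatter), so the separation from compound 2 is not specific to 7-chloroquinolin-4-yl. No supporting data bear on why these numbers fall as they do.

On these data alone, it remains open whether a single pyridine ring or a carboxylic acid on the entering group would keep the number in this range. As far as these compounds go, the effect of a longer chain on the amide side also remains open.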